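Side-chain exchange from compound 2 to compound 3

This account rests on a few compounds, and the source may have more. Where it says the series, first, only, none or still open, it means among the compounds named here.

In an ADME assay on liver for metabolic stability, with Liver microsome (Rattus norvegicus) as the target, using microsomes and NADPH, with a stated time of 30 min, tested at 0.5 uM (on this read-out higher numbers stand for fast clearance and lower numbers for slow clearance), compound 1 (`O=C1NCCN1CCOc1nn(-c2ccccc2F)c2ccc(F)cc12`) gives 1380 mL/min/kg and compound 2 (`O=C1OCCN1CCOc1nn(-c2ccccc2F)c2ccc(F)cc12`) gives 2480 mL/min/kg, so compound 2 stands level with compound 1 within the scatter. The change to compound 3 (`O=C(COc1nn(-c2ccccc2F)c2ccc(F)cc12)N1CCOCC1`), not yet measured, is (morpholin-4-yl)carbonyl in place of (2-oxo-1,3-oxazolidin-3-yl)methyl on a saturated chain carbon bound to an oxygen on an aromatic ring. In words, (morpholin-4-yl)carbonyl replaces (2-oxo-1,3-oxazolidin-3-yl)methyl on a saturated chain carbon bound to an oxygen on an aromatic ring. Among the measured compounds shown here, the only measured step bearing on this is the ring exchange in the same side chain, a 1.8-fold higher number from compound 1 to compound 2 (0.25 log units; within the scatter), which stays within the scatter. For the measured compounds named here, it is a weak guide: no measured compound carries the incoming group. No step beyond the scatter is therefore expected in this assay, and the expected step is a 1.3-fold lower number from compound 2 to compound 3 (0.12 log units; within the scatter). The estimated value for compound 3 is 1900 mL/min/kg, with an expected range of 850 mL/min/kg to 4000 mL/min/kg.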

Compound 3, clearance: 183 mL/min/kg
Estimate against measurement, compound 3: 10-fold (1.02 log units) above; the measured number lies below the stated range.
By their numbers in this assay, from the lowest: compound 3; then compounds 1 and 2 (each within the scatter of the next).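

The position is far more responsive in this assay than the ring exchange between compound 1 and compound 2 suggested, since (morpholin-4-yl)carbonyl in place of (2-oxo-1,3-oxazolidin-3-yl)methyl gives a large fall in clearance (a 14-fold lower number from compound 2 to compound 3 (1.13 log units; beyond the scatter)). The same fall appears against the other cyclic side chain (a 7.5-fold lower number from compound 1 to compound 3 (0.88 log units; beyond the scatter)), so in these three compounds it holds for both five-membered rings, and compound 3 alone stands apart from the pair.

The change replaces the ring and moves the carbonyl in a single step, so the compounds shown leave open which of the two carries the fall; 2-(morpholin-4-yl)ethyl on the same oxygen-bound chain would separate them. No supporting data bear on why the clearance fell so sharply.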